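A Chloro-Methyl Aniline on a Weakly Active Urea

The source may report more compounds than this note shows. Statements on the series, on what has been measured and on what is new or still open speak of the compounds shown alone.

For the measured compounds named here, compound 3 `O=C(Nc1ccccc1)Nc1nc(Sc2c[nH]c3ccccc23)cc(N2CCN(c3ccccn3)CC2)n1` is the only compound here with a measured number: in a functional assay on A549 cells (Homo sapiens) for inhibition, with a stated time of 72 h (a higher number here means a weaker inhibitor, a lower number a stronger inhibitor), compound 3 gives 30300 nM. Compound 1 `Cc1cc(Cl)ccc1NC(=O)Nc1nc(Sc2c[nH]c3ccccc23)cc(N2CCN(Cc3ccccc3)CC2)n1` gives > 50000 nM, which is a limit of the assay and not a number. Compound 2 `O=C(Nc1ccccc1)Nc1nc(Sc2c[nH]c3ccccc23)cc(N2CCN(Cc3ccccc3)CC2)n1` gives > 50000 nM, again a limit. Compound 4 `Cc1cc(Cl)ccc1NC(=O)Nc1nc(Sc2c[nH]c3ccccc23)cc(N2CCN(c3ccccn3)CC2)n1` differs from compound 3 by 4-chloro-2-methylphenyl in place of phenyl on an amide-type nitrogen. The same change, read in reverse, is a step that the two limits leave unreadable from compound 1 to compound 2, and its size stays hidden because both values sit at the limit of > 50000 nM in this assay, at which 2 of the 3 values shown sit. The other step, an at least 1.6-fold lower number from compound 2 to compound 3 (0.21 log units; that floor lies within the scatter), does not touch this change. No readable step predicts the direction, so compound 4 is expected to stay close to compound 3, with an expected step of a 1.3-fold higher number from compound 3 to compound 4 (0.12 log units; within the scatter). The estimate for compound 4 is 40000 nM, within 15000 nM to 110000 nM, with a fair chance that only a limit is reported.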

Compound 4, half-maximal inhibitory concentration: > 50000 nM
Compound 4: a limit, no number; the forecaster's own chance of this, stated with the estimate: 45%; middle value at least 1.2-fold (0.09 log units) away from the limit.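

Swapping phenyl for 4-chloro-2-methylphenyl on the amide-type nitrogen can now be read against a measured partner: this assay shows an at least 1.6-fold higher number from compound 3 to compound 4 (0.21 log units; that floor lies within the scatter). Compound 4 gives only a limit, so this step has a floor but no size, and a real loss cannot be told from scatter. The step from compound 1 to compound 4 cannot be read, as both stop at the same point: the limit of > 50000 nM in this assay, at which 3 of the 4 values shown sit.

Open, on these data alone, is whether the chlorine or the methyl alone would behave the same way. Also open, as far as these compounds go, is whether an amine or a carboxylic acid on that phenyl would give a clearly lower number than compound 3.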